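Weak antiproliferative series: from compound 3 to compound 4

The source may hold more compounds than are shown below. What is called first, only, known or untested is meant among the compounds shown, and "the series" means these compounds.

In a functional assay on IMR-32 cells (Homo sapiens) for antiproliferative activity, read by MTT assay (on this read-out lower numbers stand for stronger inhibition and higher numbers for weaker inhibition), compound 3 (`COc1ccc(-n2cc(COc3ccc(/C=C/C(=O)c4ccc5c(c4O)CCC(C)(C)O5)cc3)nn2)c([N+](=O)[O-])c1`) gives 132000 nM and lies within the scatter of compound 2 (`Cc1c(-n2cc(COc3ccc(/C=C/C(=O)c4ccc5c(c4O)CCC(C)(C)O5)cc3)nn2)cccc1[N+](=O)[O-]`) at 73500 nM on this read-out. Compound 1 (`CC(=O)c1ccc(-n2cc(COc3ccc(/C=C/C(=O)c4cc5c(cc4O)OC(C)(C)CC5)cc3)nn2)cc1`) is reported as "not active" (no number reported) and offers no number for comparison.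

The change to compound 4 (`Cc1ccc(-n2cc(COc3ccc(/C=C/C(=O)c4ccc5c(c4O)CCC(C)(C)O5)cc3)nn2)cc1Br`) is 3-bromo-4-methylphenyl in place of 4-methoxy-2-nitrophenyl on an aromatic nitrogen with 3-bromo-4-methylphenyl in place of 4-methoxy-2-nitrophenyl on an aromatic nitrogen, while the rest of the structure stays the same. Within the data shown here, one measured step swaps groups at this place: a 1.8-fold higher number from compound 2 to compound 3 (0.25 log units; within the scatter) is the only guide, and a single small step is thin evidence. No step beyond the scatter is therefore expected in this assay for this exchange. The expected move is a 1.3-fold lower number from compound 3 to compound 4 (0.12 log units; within the scatter) and would not count as a real change. Compound 4 could also return without a single number, as compound 1 did. For compound 4 the estimate is 100000 nM with an expected range from 35000 nM to 250000 nM if a number is reported.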

Compound 4, half-maximal inhibitory concentration: "not active" (no number reported)
The entry for compound 4 holds no number; the estimate stays without a comparison.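

In this assay, among these compounds, compound 4 gives "not active" (no number reported) and so offers no number to set against compound 3, and no step between them can be read. The compounds shown leave open how 3-bromo-4-methylphenyl compares numerically with 4-methoxy-2-nitrophenyl on the aromatic nitrogen. No evidence at hand bears on this result.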